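Capping the amine: compound 2 to compound 3

A few compounds are considered here, and "the series" means these few. Any claim that something is new, unique, unknown or untested is made for them only; others in the source may bear on it.

Measured in a functional assay with Oryctolagus cuniculus as the target; a higher number here means a weaker inhibitor, a lower number a stronger inhibitor:
Compound 1 `COc1ccc(-c2nc(CNC(C)=O)sc2-c2ccc(OC)cc2)cc1` gives 15 nM.
Compound 2 `COc1ccc(-c2nc(CN)sc2-c2ccc(OC)cc2)cc1` gives > 100 nM, which is a limit.

Compound 2 has no number, only a limit: it sits at the limit of > 100 nM in this assay, at which 1 of the 2 values shown sits. The next compound, compound 3 `CNC(=O)NCc1nc(-c2ccc(OC)cc2)c(-c2ccc(OC)cc2)s1`, differs from it by methylcarbamoyl in place of hydrogen on an amine nitrogen. Among the compounds with values here, only one measured step bears on this change: an at least 6.6-fold higher number from compound 1 to compound 2 (0.82 log units; beyond the scatter). That step is at least modest and lies beyond the scatter. It replaces acetyl with hydrogen on the same amine nitrogen, so the change to compound 3 runs the opposite way, putting a group back in place of that hydrogen. A lower number is therefore expected in this assay, with compound 1 at 15 nM as the guide. The expected size is an at least 3.3-fold lower number from compound 2 to compound 3 (0.52 log units; beyond the scatter). Methylcarbamoyl has not been measured here, so the range stays wide. For compound 3 the estimated value is 30 nM, with an expected range of 8 nM to 110 nM.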

Compound 3, half-maximal inhibitory concentration: 22 nM
For compound 3 the middle estimate is 1.4-fold (0.13 log units) above the measured one; the measured number falls inside the stated range.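

In this assay, a cap on the amine nitrogen need not be acetyl: methylcarbamoyl in place of hydrogen gives an at least 4.5-fold lower number from compound 2 to compound 3 (0.65 log units; beyond the scatter) and so becomes a second capping group that separates from the free aminomethyl compound. On these data alone, compound 2 carries a limit and not a number, so the full size of that step remains unknown. Between the two caps, methylamino in place of methyl on the carbonyl carbon gives a 1.5-fold higher number from compound 1 to compound 3 (0.17 log units; within the scatter) and so compound 1 and compound 3 cannot be ranked in this assay.

Still open, as far as these compounds go, is whether a bulkier acyl group such as benzoyl, or a methanesulfonyl group, would hold this level on the same nitrogen. Also open, from the compounds shown here alone, is whether an ethyl group there, with no carbonyl, would match these two caps.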